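Swapping methoxy for trifluoromethyl on the pyridine-type ring

This account rests on a few compounds, and the source may have more. Where it says the series, first, only, none or still open, it means among the compounds named here.

- compound 1 `COc1cc(-c2noc([C@H](C)NC(=O)c3cc(C(F)(F)F)nn3C)n2)ccn1`: 156000 nM
- compound 2 `C[C@H](NC(=O)c1cc(C(F)(F)F)nn1C)c1nc(-c2ccnc(C3CC3)c2)no1`: 16000 nM
- compound 3 `C[C@H](NC(=O)c1cc(C(F)(F)F)nn1C)c1nc(-c2ccnc(C(F)F)c2)no1`: 178000 nM

In a physicochemical assay for solubility, measured as kinetic solubility (a lower number here means a less soluble compound, a higher number a more soluble compound), compound 1 gives 156000 nM, which places it in the top pair of these three, together with compound 3 and clear of compound 2. Compound 4 `C[C@H](NC(=O)c1cc(C(F)(F)F)nn1C)c1nc(-c2ccnc(C(F)(F)F)c2)no1` is still unmeasured. It carries trifluoromethyl in place of methoxy on an aromatic carbon. Two measured changes at that same place bear on it. Difluoromethyl gave a 1.1-fold higher number from compound 1 to compound 3 (0.06 log units; within the scatter), and cyclopropyl gave a 9.8-fold lower number from compound 1 to compound 2 (0.99 log units; beyond the scatter), a modest drop. Neither group is trifluoromethyl, so the guide is loose. The expected change is a 2.6-fold lower number from compound 1 to compound 4 (0.41 log units; beyond the scatter), a small fall lying between those two steps. For compound 4 the estimated value is 60000 nM, with an expected range from 18000 nM to 170000 nM.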

Compound 4, solubility: 58000 nM
For compound 4 the middle estimate is 1.0-fold (0.01 log units) above the measured one; low and high end bracket the measured number.
By their numbers in this assay, from the lowest: compound 2; then compound 4; then compounds 1 and 3 (each within the scatter of the next).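

In this assay one more fluorine on the difluoromethyl group gives a 3.1-fold lower number from compound 3 to compound 4 (0.49 log units; beyond the scatter) and so, at this ring carbon, these two fluorinated groups are not interchangeable. Replacing methoxy with trifluoromethyl gives a 2.7-fold lower number from compound 1 to compound 4 (0.43 log units; beyond the scatter) while replacing cyclopropyl with trifluoromethyl gives a 3.6-fold higher number from compound 2 to compound 4 (0.56 log units; beyond the scatter) and this puts compound 4 in the middle of the series, clear of both ends. No measurement shown here offers a reason for these steps. Going by these compounds, how an amine, a nitrile or a plain methyl group would read at this carbon remains open.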